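Chloro on the fused ring of compound 1: expected effect

A few compounds are considered here, and "the series" means these few. Any claim that something is new, unique, unknown or untested is made for them only; others in the source may bear on it.

Measured compounds, a functional assay on KB cells (Homo sapiens) for antiproliferative activity, read by MTT assay, with a stated time of 72 h; a lower number here means a stronger inhibitor, a higher number a weaker inhibitor:
Compound 1, `CN(C(=O)c1ccccc1)c1ccc2[nH]c(-c3n[nH]c4ccccc34)cc2n1`: 8580 nM
Compound 2, `CN(C(=O)c1ccc(Br)cc1)c1ccc2[nH]c(-c3n[nH]c4ccccc34)cc2n1`: 1780 nM
Compound 3, `COc1ccc(C(=O)N(C)c2ccc3[nH]c(-c4n[nH]c5ccccc45)cc3n2)cc1`: 12900 nM

Compound 1 stands second highest of the three numbers. Among the compounds with values here, its nearest neighbour is compound 3, which sits within the scatter of it; the only step beyond the scatter is a 4.8-fold lower number from compound 1 to compound 2 (0.68 log units; beyond the scatter), and likewise a 7.2-fold higher number from compound 2 to compound 3 (0.86 log units; beyond the scatter), both of which concern the benzamide ring. The step of a 1.5-fold higher number from compound 1 to compound 3 (0.18 log units; within the scatter) stays within the scatter.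

Compound 4, `CN(C(=O)c1ccccc1)c1ccc2[nH]c(-c3n[nH]c4cc(Cl)ccc34)cc2n1`, differs from compound 1 by chloro in place of hydrogen on an aromatic carbon. This change sits on the core, on the fused six-membered carbon ring, and not on the benzamide ring where the measured changes were made. Within the data shown here, no measured step touches this ring, so nothing bears directly on it. Among the measured compounds shown here, the only halogen step available is the bromo step from compound 1 to compound 2, which lowered the number beyond the scatter, but it was made elsewhere and is at most a loose hint.

Compound 4 is therefore expected near the value of compound 1, with a possible small gain: the expected step is a 1.6-fold lower number from compound 1 to compound 4 (0.19 log units; within the scatter), and the estimate is 5500 nM, in the range 1500 nM to 18000 nM.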

Compound 4, half-maximal inhibitory concentration: 5590 nM
The estimate for compound 4 lay 1.0-fold (0.01 log units) below the measured number, and the stated range covers the measured number.
By their numbers in this assay, from the lowest: compound 2; then compounds 4, 1 and 3 (each within the scatter of the next, the first and the last beyond it).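

In this assay, chloro in place of hydrogen on an aromatic carbon of a six-membered aromatic ring of carbon only, part of a fused or bridged system of two rings, gives a 1.5-fold lower number from compound 1 to compound 4 (0.19 log units; within the scatter). Within the data shown here, this is the first reading on this part of the shared core, and it shows that this carbon can carry a chlorine atom with the number staying within the scatter of compound 1, whereas the earlier steps reported only on changes made elsewhere in the molecule. No supporting measurement is available to account for this outcome.

A single substituent at one carbon leaves open whether this position stays this flat for other groups, such as an amine, a carboxylic acid or a longer chain, any of which could move the number beyond the scatter in either direction. It also remains open whether chloro here would add to the change seen for bromo in a 4.8-fold lower number from compound 1 to compound 2 (0.68 log units; beyond the scatter), since the compounds shown do not carry both groups in one molecule.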